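The compounds below may be only part of what the source reports. "The series", "measured", "known", "first", "only" and "open" are said of these compounds alone.

Compound 1 `O=S(=O)(Nc1ccc(F)c(C#Cc2cnc3[nH]ncc3c2)c1F)c1ccccc1F`: 534 nM in a functional assay on COLO 205 cells (Homo sapiens) for antiproliferative activity, read by MTT assay, with a stated time of 68 h; a higher number here means a weaker inhibitor, a lower number a stronger inhibitor
Compound 2 `CCOc1n[nH]c2ncc(C#Cc3c(F)ccc(NS(=O)(=O)c4cccnc4)c3F)cc12`: 1980 nM in this assay

Compound 2 has the higher of these two numbers. Within the data shown here, its only neighbour, compound 1, stands apart by a gap that lies beyond the usual scatter of repeated measurements, so compound 2 is the weaker inhibitor of the pair.

Compound 3 `O=S(=O)(Nc1ccc(F)c(C#Cc2cnc3[nH]nc(-c4ccccc4Cl)c3c2)c1F)c1cccnc1` is built from compound 2 by one change: 2-chlorophenyl in place of ethoxy on an aromatic carbon. Among the measured compounds shown here, no measured pair in this set shows what such a change does, so nothing here tells which way the number should move.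

For the measured compounds named here, with no comparable step to lean on, the expectation for compound 3 is a step of a 2.0-fold lower number from compound 2 to compound 3 (0.30 log units; within the scatter) that could fall either way, most likely within or only just beyond the scatter. Compound 3 is therefore estimated at 1000 nM, with a range from 250 nM to 4000 nM.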

Compound 3, half-maximal inhibitory concentration: 3600 nM
Compound 3: the middle estimate sits 3.6-fold (0.56 log units) below what was measured, within the range that was stated.
By their numbers in this assay, from the lowest: compound 1; then compounds 2 and 3 (each within the scatter of the next).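

In this assay, 2-chlorophenyl in place of ethoxy on this aromatic carbon of the five-membered ring gives a 1.8-fold higher number from compound 2 to compound 3 (0.26 log units; within the scatter). The swap replaces a chain of 3 heavy atoms that carries one hydrogen-bond acceptor with an aromatic ring group of 7 heavy atoms and no such acceptor, yet the two compounds cannot be told apart in this measurement, so this position tolerates both groups equally in this assay. Nothing available here explains why such different groups read alike.

Going by these compounds, it remains open whether a plain phenyl without the chlorine would read the same as 2-chlorophenyl. Also open, on these data alone, is whether an amine or a carboxylic acid on this carbon would move the number beyond the scatter.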